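The compounds below may be only part of what the source reports. "The series", "measured", "known", "first", "only" and "open" are said of these compounds alone.

Measured so far

compound 1 `CCCN1CCC(CNCc2cn(-c3ccc([N+](=O)[O-])cc3)nc2-c2ccc(C(F)(F)F)cc2)CC1` — in an ADME assay on Huh-7 cells (Homo sapiens) for cytotoxicity (a higher number here means that more compound is tolerated, a lower number that less compound is tolerated), compound 1 gives 2300 nM
compound 2 `CCCN1CCC(CNCc2cn(-c3ccc(F)cc3F)nc2-c2ccccc2C)CC1` — in this assay compound 2 returns only a limit, > 20000 nM
compound 3 `Cc1ccccc1-c1nn(-c2ccc(F)cc2F)cc1CNCCCN1CCN(C)CC1` — in this assay compound 3 likewise returns only a limit, > 20000 nM

Within the data shown here, compound 1 is the one compound of the three for which this assay reports a number; the other two values are limits of the assay, as the limit of > 20000 nM in this assay, at which 2 of the 3 values shown sit, records. Compound 2 and compound 3 share a core and differ only in the change (2-(4-methylpiperazin-1-yl)ethyl in place of 1-propylpiperidin-4-yl on a saturated chain carbon bound to an amine nitrogen). The step that the two limits leave unreadable from compound 2 to compound 3 cannot be sized, since both ends sit at the limit. The cores of compound 1 and compound 2 differ in more than one place, and that difference is not broken down here.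

Compound 4 `CN1CCN(CCCNCc2cn(-c3ccc([N+](=O)[O-])cc3)nc2-c2ccc(C(F)(F)F)cc2)CC1` is not yet measured in this assay. It derives from compound 1 by 2-(4-methylpiperazin-1-yl)ethyl in place of 1-propylpiperidin-4-yl on a saturated chain carbon bound to an amine nitrogen, the same change as that from compound 2 to compound 3, at the same place. The measured pair gives no size for this change, so the expectation for compound 4 rests on compound 1 alone, whose value 2300 nM is the only anchor. The step of a 1.5-fold higher number from compound 1 to compound 4 (0.18 log units; within the scatter) is therefore expected to be small, with wide uncertainty in either direction. For compound 4 in this assay a value of about 3500 nM is estimated, expected to fall between 1000 nM and 15000 nM.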

Compound 4, half-maximal cytotoxic concentration: 4900 nM
Estimate against measurement, compound 4: 1.4-fold (0.15 log units) below; the measured number falls inside the stated range.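

On the core of compound 1, 2-(4-methylpiperazin-1-yl)ethyl in place of 1-propylpiperidin-4-yl gives, in this assay, a 2.1-fold higher number from compound 1 to compound 4 (0.33 log units; beyond the scatter), so on this core the change has a readable, modest size. The same change on the core of compound 2 cannot be read, since compound 2 and compound 3 both return only a limit: the limit of > 20000 nM in this assay, at which 2 of the 4 values shown sit. The series therefore holds one sized example of this change, which shows its direction and size on the core of compound 1 but does not show that either carries over to the core of compound 2, or that the two cores respond alike or differently.

Still open, going by these compounds, is whether a longer chain in the 2-(4-methylpiperazin-1-yl)ethyl group, or a morpholine ring in its place, would move the number on the core of compound 1. Also open, on these data alone, is whether the change gives a step of similar size on any further core whose values can be read as numbers rather than limits.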